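Removing the primary amine from the cyclopropanecarboxamide series

The source may report more compounds than this note shows. Statements on the series, on what has been measured and on what is new or still open speak of the compounds shown alone.

Compound 1, `CC(C)C[C@H](N)CN(C(=O)[C@@H]1C[C@H]1c1ccccc1)c1ccc(-c2ccccc2)cc1`, is the reference point of this small set. Among the measured compounds shown here, in a functional assay for agonist activity at G protein-coupled receptor 88 (Homo sapiens), read by HTRF and cAMP accumulation (a higher number here means that more compound is needed for the effect, a lower number that less compound is needed), compound 1 gives 880 nM, the only value it has there, with one further entry that does not come down to a single number. Compound 2, `CC[C@H](C)[C@H](N)CN(C(=O)[C@@H]1C[C@H]1c1ccccc1)c1ccc(-c2ccccc2)cc1`, is the other measured member; in this assay compound 2 gives 230 nM; 800 nM (2 entries), and the several entries of compound 2 in this assay, 230 nM; 800 nM (2 entries) shows how far repeats of one compound can spread here. Compound 3, `CC(C)CCCN(C(=O)[C@@H]1C[C@H]1c1ccccc1)c1ccc(-c2ccccc2)cc1`, has not been measured. It differs from compound 1 by hydrogen in place of amino on a saturated chain carbon bound to two saturated chain carbons. For the measured compounds named here, no measured pair in the set separates the effect of this change, so the direction rests on the loss of the amino group alone. The expected step from compound 1 to compound 3 in this assay is a 4.5-fold higher number from compound 1 to compound 3 (0.66 log units; beyond the scatter), toward needing more compound. Compound 3 is estimated at 4000 nM, within 1000 nM to 20000 nM.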

Compound 3, half-maximal effective concentration: > 100 nM
Compound 3 was reported as a limit; the forecaster's own chance of this, stated with the estimate: 30%; the middle value is on the limit's open side.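

In this assay compound 3 gives > 100 nM, which is a limit and not a number. Among the compounds shown here, no step between compound 1 and compound 3 can be read from it. The compounds shown leave open whether hydrogen in place of amino shifts the value, and by how much.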